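The compounds below may be only part of what the source reports. "The series", "measured", "known", "first", "only" and "open" are said of these compounds alone.

Measured in a functional assay on PC-3 cells (Homo sapiens) for cytotoxicity, read by MTT assay, with a stated time of 72 h; a higher number here means a weaker inhibitor, a lower number a stronger inhibitor:
- compound 1 `Cc1ccc(S(=O)(=O)n2cc(COC3=C/C(=N\c4ccc(I)cc4)c4ccccc4C3=O)nn2)cc1`: > 16300 nM (a limit of the assay)
- compound 2 `Cc1ccc(S(=O)(=O)n2cc(COC3=C/C(=N\c4ccc(Br)cc4)c4ccccc4C3=O)nn2)cc1`: 3410 nM
- compound 3 `Cc1ccc(S(=O)(=O)n2cc(COC3=C/C(=N\c4ccc(F)cc4)c4ccccc4C3=O)nn2)cc1`: 2030 nM

Among the measured compounds shown here, compound 2 and compound 3 are the only two with exact numbers, and they lie within the scatter of each other: a 1.7-fold lower number from compound 2 to compound 3 (0.23 log units; within the scatter). The value for compound 1 is a limit and not a number.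

Compound 4 `COc1ccc(/N=C2\C=C(OCc3cn(S(=O)(=O)c4ccc(C)cc4)nn3)C(=O)c3ccccc32)cc1` has not yet been measured. It takes compound 3 and places methoxy in place of fluoro on an aromatic carbon, para to a large group: methoxy in place of fluoro on an aromatic carbon.

For the measured compounds named here, no measured step involves methoxy, so the evidence is indirect and comes from changes of halogen at the same place. The swap between bromo and fluoro gave a 1.7-fold lower number from compound 2 to compound 3 (0.23 log units; within the scatter), while the two steps away from iodo were larger: an at least 4.7-fold lower number from compound 1 to compound 2 (0.67 log units; beyond the scatter) and an at least 8.0-fold lower number from compound 1 to compound 3 (0.90 log units; beyond the scatter). Only the iodo compound stands apart from the others, so a group change at this place can matter, but it need not.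

A small move towards a higher number in this assay is expected, close to the scatter, with a wide margin on the upper side. The estimated change is a 1.7-fold higher number from compound 3 to compound 4 (0.24 log units; within the scatter). The expected value for compound 4 is 3500 nM, with an estimated range from 1200 nM to 12000 nM.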

Compound 4, half-maximal inhibitory concentration: > 20000 nM
Compound 4: a limit, no number; the forecaster's own chance of this, stated with the estimate: 12%; at least 5.7-fold (0.75 log units) between middle value and limit.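

Compound 4 gives > 20000 nM in this assay and this is a limit of the assay, not a number. Even so, the change from 4-fluorophenyl to 4-methoxyphenyl gives an at least 9.8-fold higher number from compound 3 to compound 4 (0.99 log units; beyond the scatter) and methoxy in place of bromo at the same place gives an at least 5.8-fold higher number from compound 2 to compound 4 (0.76 log units; beyond the scatter) so both readable steps lie beyond the scatter. Before this, only the iodo group of compound 1 set a compound apart from compound 2 and compound 3, which lie within the scatter of each other; methoxy in compound 4 now does so as well, which shows that the rise in the number at this position is not confined to iodo.

Compound 1 and compound 4 both carry limits, and the step between them cannot be read. As far as these compounds go, it remains open whether an amine, a hydroxyl or a longer chain such as ethoxy at this place would stay with fluoro and bromo or go with iodo and methoxy, and how far past their limits compound 1 and compound 4 truly lie.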